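The source may report more compounds than this note shows. Statements on the series, on what has been measured and on what is new or still open speak of the compounds shown alone.

Of the compounds shown here, two sharing one core have been measured in a functional assay on MCF7 cells (Homo sapiens) for antiproliferative activity, read by MTT assay, with a stated time of 72 h; on this read-out higher numbers stand for weaker inhibition and lower numbers for stronger inhibition. Compound 1 `CCN1CCN(c2cc(C)c3cc(NC(=O)c4ccccc4C)ccc3n2)CC1` gives 10900 nM, the lower of the two numbers. Compound 2 `Cc1cc(N2CCCCC2)nc2ccc(NC(=O)c3ccc(Cl)c(Cl)c3)cc12` gives 31100 nM in this assay, a gap beyond the usual scatter. Compound 3 `CCN1CCN(c2cc(C)c3cc(NC(=O)c4ccco4)ccc3n2)CC1` has not yet been measured; it differs from compound 1 in one place: furan-2-yl in place of 2-methylphenyl on a carbonyl carbon. Among the compounds with values here, no measured pair shows this change, so its effect is unknown here. A step of a 1.4-fold higher number from compound 1 to compound 3 (0.14 log units; within the scatter) is expected in this assay, not beyond the scatter. The estimate for compound 3 is 15000 nM, with a range from 5000 nM to 45000 nM.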

Compound 3, half-maximal inhibitory concentration: 41200 nM
Estimate against measurement, compound 3: 2.7-fold (0.44 log units) below; low and high end bracket the measured number.
By their numbers in this assay, from the lowest: compound 1; then compounds 2 and 3 (each within the scatter of the next).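

Furan-2-yl in place of 2-methylphenyl on a carbonyl carbon gives a 3.8-fold higher number from compound 1 to compound 3 (0.58 log units; beyond the scatter) in this assay and so weakens inhibition modestly. Within the data shown here, this is the first change in one place only, and it shows that the group on this carbonyl carbon affects the read-out while the rest of compound 1 stays the same. Nothing measured here accounts for the step.

A single pair cannot separate the change of ring from the loss of the methyl group. As far as these compounds go, how a plain phenyl, a cyclohexyl ring or a longer alkyl chain would read at this place remains open.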